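Halogen swap on the benzyl arm of compound 2

This account rests on a few compounds, and the source may have more. Where it says the series, first, only, none or still open, it means among the compounds named here.

Among the compounds with values here, compound 2 `COc1ccc(C(=O)/C=C/c2ccc(OCc3cn(Cc4ccc(Br)cc4)nn3)cc2)cc1` gives 9000 nM in a functional assay on MCF7 cells (Homo sapiens) for cytotoxicity, read by MTT assay, with a stated time of 48 h (on this read-out lower numbers stand for stronger inhibition and higher numbers for weaker inhibition), the highest of the two numbers measured so far; its nearest neighbour, compound 1 `COc1ccc(C(=O)/C=C/c2ccc(OCc3cn(Cc4ccccc4)nn3)cc2)cc1`, gives 5000 nM in this assay. Within the data shown here, the only measured step, a 1.8-fold higher number from compound 1 to compound 2 (0.26 log units; within the scatter), is the one that bears on this part of the molecule. Compound 3 `COc1ccc(C(=O)/C=C/c2ccc(OCc3cn(Cc4cccc(F)c4)nn3)cc2)cc1` carries 3-fluorophenyl in place of 4-bromophenyl on a saturated chain carbon bound to an aromatic nitrogen. Among the measured compounds shown here, with one step of that small size as the only guide, compound 3 is expected to differ from compound 2 by a 1.4-fold lower number from compound 2 to compound 3 (0.14 log units; within the scatter), nothing beyond the scatter. Compound 3 is therefore estimated at 6500 nM, with a range from 2500 nM to 17000 nM.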

Compound 3, half-maximal inhibitory concentration: 55000 nM
Estimate against measurement, compound 3: 8.5-fold (0.93 log units) below, outside the stated range (above it).
By their numbers in this assay, from the lowest: compounds 1 and 2 (each within the scatter of the next); then compound 3.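

This position proved sensitive to substitution in a way the bromo step had not shown: with 3-fluorophenyl on the saturated chain carbon, there is a 6.1-fold higher number from compound 2 to compound 3 (0.79 log units; beyond the scatter), and the same arm, set against the arm without a halogen, brings an 11-fold higher number from compound 1 to compound 3 (1.04 log units; beyond the scatter). A single halogen on this ring can thus weaken the read-out well beyond the scatter, although the bromo of compound 2 stays within the scatter of compound 1. Nothing available explains this difference.

The compounds shown leave open whether the loss follows the fluorine or its ring position, as halogen and position change together. On these data alone, how 4-fluorophenyl, 3-bromophenyl or a benzyl arm bearing an amine would read also remains open.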